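Fluoro-to-hydrogen step on the phenylpiperazine partner

This account rests on a few compounds, and the source may have more. Where it says the series, first, only, none or still open, it means among the compounds named here.

Working notes on the series. Compound 1 `CS(=O)(=O)c1ccc(C(=O)N2CCC(C(=O)N3CCc4ccccc43)CC2)cc1[N+](=O)[O-]` and compound 2 `CN(CC(=O)N1CCN(c2ccc(F)cc2)CC1)C(=O)c1ccc(S(C)(=O)=O)c([N+](=O)[O-])c1` share the same core on different amine partners. Within the data shown here, in an ADME assay on HepG2 cells (Homo sapiens) for cytotoxicity, read by CellTiter-Glo and ATP content, with a stated time of 72 h (on this read-out higher numbers stand for an effect only at larger amounts of compound and lower numbers for an effect already at smaller amounts), compound 2 gives 17200 nM, the only number reported for the set so far. For compound 1 the result in this assay is a limit, > 27000 nM, not a number. Compound 2 thus stands as the sole measured point, the other entry sitting at the limit of > 27000 nM in this assay, at which 1 of the 2 values shown sits.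

Compound 3 `CN(CC(=O)N1CCN(c2ccccc2)CC1)C(=O)c1ccc(S(C)(=O)=O)c([N+](=O)[O-])c1` differs from compound 2 by hydrogen in place of fluoro on an aromatic carbon, read one bond further out as 4-fluorophenyl to phenyl. Among the measured compounds shown here, no measured step of this kind exists, so no size can be drawn from the data; a change this small is expected to stay within the scatter, with no clear direction. Compound 3 is therefore estimated at 20000 nM in this assay, ranging from 9000 nM to 45000 nM. The expected step of a 1.2-fold higher number from compound 2 to compound 3 (0.07 log units; within the scatter) amounts to no change beyond the scatter.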

Compound 3, half-maximal effective concentration: > 27000 nM
Compound 3: only a limit was reported; the forecaster's own chance of this, stated with the estimate: 35%; middle value at least 1.3-fold (0.13 log units) away from the limit.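

The 4-fluorophenyl to phenyl change gives the series its first step at this position: in this assay, the step is an at least 1.5-fold higher number from compound 2 to compound 3 (0.19 log units; that floor lies within the scatter). The result for compound 3 is a limit of the assay, not a number. The floor of the step lies within the scatter and its true size cannot be read, so the data do not separate fluoro from hydrogen here, because the read-out ends at a limit that most of the set has reached: the limit of > 27000 nM in this assay, at which 2 of the 3 values shown sit.

Among these compounds, compound 2 remains the only compound with a number, so the series offers no second number against which to size this change. Open, going by these compounds, is how chloro or methoxy on the same aromatic carbon would read in this assay, and whether either would give a number rather than a limit.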